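The source may report more compounds than this note shows. Statements on the series, on what has been measured and on what is new or still open speak of the compounds shown alone.

Within the data shown here, compound 1 `COc1cc(N)c(Cl)cc1C(=O)NC1CCN(CC2CCN(CC(C)CN)CC2)CC1` and compound 2 `COc1cc(N)c(Cl)cc1C(=O)NC1CCN(C(=O)C2CCN(C(=O)CCCN)CC2)CC1` share the same core and differ in several places at once, so no single step between them can be read. In an assay on striatum for inhibition of 5-hydroxytryptamine receptor 4 (Cavia porcellus), read by radioligand binding (on this read-out higher numbers stand for weaker inhibition and lower numbers for stronger inhibition), compound 1 gives 14.3 nM, and compound 2 gives 425 nM. Compound 1 therefore stands at the lowest of the two numbers, with compound 2 showing a markedly higher number, a gap beyond the usual scatter. The unmeasured compound 3 `COc1cc(N)c(Cl)cc1C(=O)NC1CCN(CC2CCN(C(=O)CN)CC2)CC1` differs from compound 1 by (aminomethyl)carbonyl in place of 2-(aminomethyl)propyl on an amine nitrogen in a ring. Since compound 2, which also carries carbonyls on its ring nitrogens, gives 425 nM, the step from compound 1 to compound 3 is expected to run toward a higher number, by a 5.6-fold higher number from compound 1 to compound 3 (0.75 log units; beyond the scatter), a moderate loss rather than the whole gap seen for compound 2. Compound 3 is accordingly estimated at 80 nM, with a range from 20 nM to 400 nM.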

Compound 3, half-maximal inhibitory concentration: 9.3 nM
Estimate against measurement, compound 3: 8.6-fold (0.93 log units) above; measured number below the stated range.
By their numbers in this assay, from the lowest: compounds 3 and 1 (each within the scatter of the next); then compound 2.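

In this assay, placing (aminomethyl)carbonyl in place of 2-(aminomethyl)propyl on the amine nitrogen in the ring leaves the number level, with a 1.5-fold lower number from compound 1 to compound 3 (0.19 log units; within the scatter). This position therefore accepts a carbonyl on that nitrogen without a measurable loss, while the steps to compound 2, at 425 nM, cannot be read, since compound 2 differs from compound 1 and compound 3 in several places. Nothing at hand explains why the exchange leaves the number level.

The compounds shown leave open whether the terminal primary amine matters at this nitrogen, as an acetyl group or a carboxylic acid in its place would test. They also leave open how a longer aminoalkyl chain on the carbonyl would read when the rest of compound 3 is unchanged.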